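Restoring the Third Methoxy on the Aryl Ring

The source may report more compounds than this note shows. Statements on the series, on what has been measured and on what is new or still open speak of the compounds shown alone.

Compound 3 `COc1ccc(-c2nc3cc(/C=C4\SC(=O)N(CC(=O)N5CCOCC5)C4=O)ccc3[nH]2)cc1OC` stands in a functional assay on PC-3 cells (Homo sapiens) for inhibition, read by MTT assay, with a stated time of 48 h (a lower number here means a stronger inhibitor, a higher number a weaker inhibitor), only as a limit: compound 3 gives > 50000 nM, a value sitting at the limit of > 50000 nM in this assay, at which 1 of the 3 values shown sits. Compound 1 `COc1cc(OC)c(-c2nc3cc(/C=C4\SC(=O)NC4=O)ccc3[nH]2)cc1OC` gives 6320 nM and compound 2 `COc1cc(-c2nc3cc(/C=C4\SC(=O)N(CC(=O)N5CCOCC5)C4=O)ccc3[nH]2)cc(OC)c1OC` gives 5940 nM, two numbers within the scatter of each other. Compound 4 `COc1cc(OC)c(-c2nc3cc(/C=C4\SC(=O)N(CC(=O)N5CCOCC5)C4=O)ccc3[nH]2)cc1OC` differs from compound 3 by methoxy in place of hydrogen on an aromatic carbon. For the measured compounds named here, the one measured step that bears on this change is an at least 8.4-fold higher number from compound 2 to compound 3 (0.92 log units; beyond the scatter), where removal of a methoxy group gave a large loss; adding a methoxy group back is expected to reverse it. Compound 4 carries the same 2,4,5-trimethoxyphenyl as compound 1, and compound 1 gives 6320 nM. Compound 4 is therefore expected at about 7000 nM, within 2500 nM to 25000 nM. That estimate means a step of an at least 7.1-fold lower number from compound 3 to compound 4 (0.85 log units; beyond the scatter).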

Compound 4, half-maximal inhibitory concentration: 11700 nM
Compound 4: middle estimate off by 1.7-fold (0.22 log units), on the low side, within the range that was stated.
By their numbers in this assay, from the lowest: compounds 2, 1 and 4 (each within the scatter of the next). At a limit, above all of these: compound 3.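

In this assay methoxy ortho to a large group gave an at least 4.2-fold lower number from compound 3 to compound 4 (0.63 log units; beyond the scatter) so a third methoxy need not occupy the place it holds in compound 2. The 2,4,5-trimethoxyphenyl and 3,4,5-trimethoxyphenyl patterns could not be told apart, with a 2.0-fold higher number from compound 2 to compound 4 (0.29 log units; within the scatter) and the ((morpholin-4-yl)carbonyl)methyl group likewise made no difference beyond the scatter, with a 1.9-fold higher number from compound 1 to compound 4 (0.27 log units; within the scatter) on this aryl ring. The first step rests on a limit for compound 3: the limit of > 50000 nM in this assay, at which 1 of the 4 values shown sits.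

On these data alone, whether an amine, a hydroxyl group or a longer alkoxy chain could stand in place of this methoxy remains open.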